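A few compounds are considered here, and "the series" means these few. Any claim that something is new, unique, unknown or untested is made for them only; others in the source may bear on it.

Compound 1 `COc1ccc2[nH]c(C(=O)N3CC(=O)N(Cc4ccccc4)[C@@H](CN4CCC(OC)CC4)C3)cc2c1` was examined in a physicochemical assay for solubility, read by spectrophotometry, in phosphate buffer, with a stated time of 2 h, at pH 7.4; on this read-out lower numbers stand for lower solubility and higher numbers for higher solubility. In this assay compound 1 gives > 25000 nM, which is a limit of the assay rather than a number, namely (the limit of > 25000 nM in this assay, at which 1 of the 2 values shown sits). Compound 2 `COc1ccc2[nH]c(C(=O)N3CC(=O)N(Cc4c[nH]c5ccccc45)[C@@H](Cc4ccccc4)C3)cc2c1` is the other measured compound, and in this assay compound 2 gives 10300 nM. Compound 3 `COc1ccc2[nH]c(C(=O)N3CC(=O)N(Cc4ccccc4)[C@@H](CN4CCC(C(C)C)CC4)C3)cc2c1` has not yet been measured; it differs from compound 1 by isopropyl in place of methoxy on a saturated ring carbon. Going by the values given here, no measured step of this kind is available, so the expected step rests on the structural change alone: an at least 3.1-fold lower number from compound 1 to compound 3 (0.49 log units; beyond the scatter), toward lower solubility and beyond the scatter. Compound 3 is therefore estimated at 8000 nM, within a range from 2000 nM to 25000 nM.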

Compound 3, solubility: 12000 nM
Beside the measured number, compound 3's estimate is 1.5-fold (0.18 log units) below it, and the stated range covers the measured number.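

Going by these compounds alone, putting isopropyl in place of methoxy on a saturated ring carbon, three ring bonds from the ring nitrogen, gives the first step at this position in this assay: an at least 2.0-fold lower number from compound 1 to compound 3 (0.31 log units; beyond the scatter). The change thus moves the series from the top of the read-out to a number that can be read. Compound 1 stands at a limit of the assay and not at a number, so the full size of the step remains unknown: the limit of > 25000 nM in this assay, at which 1 of the 3 values shown sits.

Still open, as far as these compounds go, is how a hydroxyl, an amine or a carboxylic acid on this ring carbon would read in this assay. Also open, from the compounds shown here alone, is whether a longer chain there would lower the number further.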